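A few compounds are considered here, and "the series" means these few. Any claim that something is new, unique, unknown or untested is made for them only; others in the source may bear on it.

Working notes on the amide series, read in an ADME assay on Vero cells (Chlorocebus sabaeus) for cytotoxicity, read by resazurin assay; a higher number here means a weaker inhibitor, a lower number a stronger inhibitor. Compound 1 (`Cc1cc(C)c2cc(C(=O)Nc3ccncc3)[nH]c2c1`) has no number to stand on, its entry being "not determined" (no result reported). Compound 2 (`Cc1cc(C)c2cc(C(=O)NC3CCN(C)CC3)[nH]c2c1`) has the same entry, "not determined" (no result reported). The only numerical anchor is therefore compound 3 (`Cc1cc(C)c2cc(C(=O)NC3CCCCCCC3)[nH]c2c1`), which gives 54000 nM.

Compound 4 (`Cc1cc(C)c2cc(C(=O)NCC3CCCCC3)[nH]c2c1`) keeps the shared core and changes only the amide substituent: cyclohexylmethyl in place of pyridin-4-yl on an amide-type nitrogen. In words, cyclohexylmethyl comes in place of pyridin-4-yl on an amide-type nitrogen. With no value for compound 1, no size or direction can be given for a step from it in this assay. The entering group has a non-aromatic ring of carbon only, and compound 3 also carries such a ring on its amide nitrogen. The expectation therefore rests on compound 3 at 54000 nM, with no difference beyond the scatter expected from that value, in either direction. One compound is a thin basis, so the range is kept wide. For compound 4 the estimated value is 50000 nM, with an expected range of 20000 nM to 120000 nM.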

Compound 4, half-maximal inhibitory concentration: > 200000 nM
Compound 4 ended at the assay's limit; the forecaster's own chance of this, stated with the estimate: 35%; middle value at least 4.0-fold (0.60 log units) from the limit.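

Among the compounds shown here, no step from compound 1 to compound 4 can be read in this assay, as compound 1 has no single number. Compound 4 gives > 200000 nM, which is a limit of the assay and not a number. The compounds shown leave open how the amide substituent bears on the read-out.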